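The compounds below may be only part of what the source reports. "The series", "measured", "known", "first", "only" and "open" are said of these compounds alone.

Series notes. Compound 1 `Cc1ccc(-c2nc(N)c3ccsc3n2)o1` gives 493 nM in a functional assay on CHO-K1 cells for antagonist activity at adenosine receptor A1 (Homo sapiens), read by a beta-galactosidase reporter and cAMP accumulation, with stated times of 15 min and 6 h; a lower number here means a stronger inhibitor, a higher number a weaker inhibitor. Compound 2 `Cc1ccc(-c2nc(N)c3cc(Cc4ccccc4)sc3n2)o1` carries a benzyl in place of hydrogen on an aromatic carbon and gives 298 nM; the step of a 1.7-fold lower number from compound 1 to compound 2 (0.22 log units; within the scatter) is within the scatter. Compound 3 `Nc1nc(-c2ccc(C3CC3)o2)nc2sc(Cc3ccccc3)cc12`, with cyclopropyl in place of methyl on an aromatic carbon, gives 861 nM, and the step of a 2.9-fold higher number from compound 2 to compound 3 (0.46 log units; beyond the scatter) is a modest rise beyond the scatter. Compound 2 thus holds the lowest number of the three, though compound 1 sits within the scatter of it.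

Compound 4 `Nc1nc(-c2ncco2)nc2sc(Cc3ccccc3)cc12` differs from compound 2 by 1,3-oxazol-2-yl in place of 5-methylfuran-2-yl on an aromatic carbon. Among the compounds with values here, no measured step touches this exchange directly. Within the data shown here, the only step at that part of the structure is a 2.9-fold higher number from compound 2 to compound 3 (0.46 log units; beyond the scatter), where a change of the group on the five-membered ring gave a modest rise; exchanging the whole ring, and losing the methyl with it, is a larger change and is expected to carry a rise at least as large, with wide uncertainty. The estimated step is a 3.0-fold higher number from compound 2 to compound 4 (0.48 log units; beyond the scatter). For compound 4 the expected value in this assay is 900 nM, with a range of 300 nM to 2700 nM.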

Compound 4, inhibition constant: 310 nM
The estimate for compound 4 lay 2.9-fold (0.46 log units) above the measured number; measured number inside the range.
By their numbers in this assay, from the lowest: compounds 2, 4, 1 and 3 (each within the scatter of the next, the first and the last beyond it).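

At this place on the shared core, between two ring nitrogen atoms, the whole five-membered aromatic ring can be exchanged in this assay without a reading beyond the scatter: 1,3-oxazol-2-yl in place of 5-methylfuran-2-yl gives a 1.0-fold higher number from compound 2 to compound 4 (0.02 log units; within the scatter). The position therefore does not penalise every change, since the rise with 5-cyclopropylfuran-2-yl is not shared by the oxazole, and the exchange of that group for 1,3-oxazol-2-yl gives a 2.8-fold lower number from compound 3 to compound 4 (0.44 log units; beyond the scatter). Nothing available accounts for this difference between the groups.

Open, going by these compounds, is whether the tolerance extends to other rings at this place, such as thiazol-2-yl, phenyl or unsubstituted furan-2-yl. Also open, on these data alone, is whether a methyl or a cyclopropyl on the oxazole would give the same rise as the cyclopropyl on the furan.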